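Aryl group variation at the ring amine nitrogen

A few compounds are considered here, and "the series" means these few. Any claim that something is new, unique, unknown or untested is made for them only; others in the source may bear on it.

Compound 1 `O=C1c2ccccc2S(=O)(=O)N1CCCCCCN1CCN(c2cccc(Cl)c2Cl)CC1`: in an assay on HEK293 cells for displacement of a labelled ligand from 5-hydroxytryptamine receptor 7 (Homo sapiens) (a lower number here means a stronger inhibitor, a higher number a weaker inhibitor), compound 1 gives 487 nM.
Compound 2 `COc1ccccc1N1CCN(CCCCCCN2C(=O)c3ccccc3S2(=O)=O)CC1`: in this assay compound 2 gives 105 nM.

Compound 2 stands lowest of the two numbers measured, the step of a 4.6-fold lower number from compound 1 to compound 2 (0.67 log units; beyond the scatter) lying beyond the scatter. Compound 3 `O=C1c2ccccc2S(=O)(=O)N1CCCCCCN1CCN(c2ccc(Cl)cc2)CC1` differs from compound 2 in one place: 4-chlorophenyl in place of 2-methoxyphenyl on an amine nitrogen in a ring. For the measured compounds named here, no measured step matches this change directly; the only one that bears on it is a 4.6-fold lower number from compound 1 to compound 2 (0.67 log units; beyond the scatter), where 2,3-dichlorophenyl gave the higher number and 2-methoxyphenyl the lower. A modest rise in this assay is therefore expected for compound 3, smaller than that step. Compound 3 is estimated at 300 nM, range 100 nM to 900 nM, an expected step of a 2.9-fold higher number from compound 2 to compound 3 (0.46 log units; beyond the scatter).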

Compound 3, inhibition constant: 487 nM
The estimate for compound 3 lay 1.6-fold (0.21 log units) below the measured number; the range from low to high includes it.
By their numbers in this assay, from the lowest: compound 2; then compounds 1 and 3 (each within the scatter of the next).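

In this assay, the change at this amine nitrogen gives a 4.6-fold higher number from compound 2 to compound 3 (0.67 log units; beyond the scatter), so 2-methoxyphenyl now stands apart from two chlorine-bearing aryl groups rather than one. Those two groups cannot be told apart here, with no change at the digits printed from compound 1 to compound 3 (within the scatter), so 4-chlorophenyl and 2,3-dichlorophenyl serve equally in this comparison. No measurement available offers an explanation for this result.

Still open, on these data alone, is whether the lower number of compound 2 follows the methoxy group itself or where it sits on the phenyl ring; 4-methoxyphenyl and 2-chlorophenyl would separate the two.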